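Oxime Geometry Versus Isoxazole in an Imidazoline Series

The compounds below may be only part of what the source reports. "The series", "measured", "known", "first", "only" and "open" are said of these compounds alone.

Compound 1 `Cc1cc(-c2ccccc2NCC2=NCCN2)on1`: 95.5 nM
Compound 2 `CC/C(=N\OC)c1ccccc1NCC1=NCCN1`: < 100000 nM

In a functional assay for activation of Alpha-1B adrenergic receptor (Homo sapiens), read by calcium flux (on this read-out higher numbers stand for an effect only at larger amounts of compound and lower numbers for an effect already at smaller amounts), compound 1 gives 95.5 nM. Compound 2 reaches only a limit of the assay, < 100000 nM. The step that the limit leaves unreadable from compound 1 to compound 2 therefore has no readable size, as the entry the limit of < 100000 nM in this assay, at which 1 of the 2 values shown sits, records. Compound 3 `CC/C(=N/OC)c1ccccc1NCC1=NCCN1` shares every atom and bond with compound 2 and differs only in the two compounds have the same atoms and bonds and differ only in configuration as drawn: 1 of 1 stereo elements differ; a double bond is drawn E in compound 2 and Z in compound 3. Going by the values given here, no measured step touches this kind of change, and compound 2 itself offers no number to move from. Compound 3 is thus expected to remain at the same limit, an expected step of a number no lower from compound 2 to compound 3 (the limit leaves the size open) in this assay, with an estimate of 100000 nM and a range from 20000 nM to 300000 nM.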

Compound 3, half-maximal effective concentration: < 5020 nM
Compound 3: no number, only a limit; the forecaster's own chance of this, stated with the estimate: 80%; middle value at least 19-fold (1.29 log units) away from the limit.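

In this assay compound 3 gives only a limit, < 5020 nM. Going by these compounds alone, no step linking compound 1, compound 2 and compound 3 can be read. The compounds shown leave open whether drawing the double bond E or Z changes activation at all.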